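Dimethoxyphenyl for dimethylphenyl on the carbonyl of compound 3

This account rests on a few compounds, and the source may have more. Where it says the series, first, only, none or still open, it means among the compounds named here.

Measured compounds:
compound 1 `COc1ccc(-c2cc(/C=C/C(=O)c3ccc(OC)c(OC)c3)nc3cc(-c4ccccc4)nn23)cc1`: 48500 nM
compound 2 `COc1ccc(C(=O)/C=C/c2cc(-c3ccc(OC)c(OC)c3)n3nc(-c4ccccc4)cc3n2)cc1OC`: 32500 nM
compound 3 `COc1cc(-c2cc(/C=C/C(=O)c3ccc(C)c(C)c3)nc3cc(-c4ccccc4)nn23)cc(OC)c1OC`: 72500 nM

The three measured compounds share one core and differ in the substituents on the two outer aromatic rings. Among the measured compounds shown here, in an ADME assay on HEK293 cells (Homo sapiens) for antiproliferative activity, read by MTT assay, with a stated time of 24 h (on this read-out higher numbers stand for weaker inhibition and lower numbers for stronger inhibition), compound 1 gives 48500 nM and compound 2 gives 32500 nM; the step of a 1.5-fold lower number from compound 1 to compound 2 (0.17 log units; within the scatter) is the only single change among the measured pairs. In this assay compound 3 gives 72500 nM, the highest of the three numbers, though its gap to compound 1 lies within the scatter and only its gap to compound 2 lies beyond it.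

Compound 4 `COc1ccc(C(=O)/C=C/c2cc(-c3cc(OC)c(OC)c(OC)c3)n3nc(-c4ccccc4)cc3n2)cc1OC` has not yet been measured. It differs from compound 3 in one place: 3,4-dimethoxyphenyl in place of 3,4-dimethylphenyl on a carbonyl carbon. For the measured compounds named here, the one measured step that bears on this, from compound 1 to compound 2, also adds methoxy groups to an outer aromatic ring and stays within the scatter. Compounds 1 and 2 already carry the 3,4-dimethoxyphenyl on the carbonyl carbon and give numbers of the same order as compound 3. The expected step of a 1.5-fold lower number from compound 3 to compound 4 (0.16 log units; within the scatter) is therefore small, a slightly lower number at most. Compound 4 is estimated to give 50000 nM in this assay, in a range from 20000 nM to 120000 nM.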

Compound 4, half-maximal inhibitory concentration: 81700 nM
Compound 4: middle estimate off by 1.6-fold (0.21 log units), on the low side; the range from low to high includes it.
By their numbers in this assay, from the lowest: compounds 2, 1, 3 and 4 (each within the scatter of the next, the first and the last beyond it).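

In this assay, putting 3,4-dimethoxyphenyl in place of 3,4-dimethylphenyl on a carbonyl carbon gives a 1.1-fold higher number from compound 3 to compound 4 (0.05 log units; within the scatter) and so, with the 3,4,5-trimethoxyphenyl group held fixed, the data do not separate these two groups at this position. The group on the aromatic carbon now shows a step beyond the scatter, a 2.5-fold higher number from compound 2 to compound 4 (0.40 log units; beyond the scatter), while a 1.5-fold lower number from compound 1 to compound 2 (0.17 log units; within the scatter) and a 1.7-fold higher number from compound 1 to compound 4 (0.23 log units; within the scatter) both stay within it, so the numbers do not follow a steady trend with the count of methoxy groups, and compound 1 goes against any such trend. No supporting measurement is available to explain either the flat step on the carbonyl carbon or the larger step on the aromatic carbon.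

The compounds shown leave open whether any group on the carbonyl carbon can move the number beyond the scatter, since only 3,4-dimethylphenyl and 3,4-dimethoxyphenyl are compared there. As far as these compounds go, a phenyl ring carrying an amine or a carboxylic acid at that place would test this, and it also remains open whether the flat step holds when the group on the aromatic carbon is 3,4-dimethoxyphenyl or 4-methoxyphenyl.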